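The source may hold more compounds than are shown below. What is called first, only, known or untested is meant among the compounds shown, and "the series" means these compounds.

Of the compounds shown here, three have been measured in an assay for inhibition of kynurenine 3-monooxygenase (Homo sapiens), read by mass spectrometry, with a stated time of 1 h; on this read-out lower numbers stand for stronger inhibition and higher numbers for weaker inhibition. Compound 1, `Cc1ccc([C@@H](C)Oc2cc3onc(CCC(=O)O)c3cc2Cl)nc1`, gives 3.16 nM in this assay. Compound 2, `C[C@@H](Oc1cc2oc(=O)n(CCC(=O)O)c2cc1Cl)c1ccc(F)cn1`, gives 2.51 nM in this assay. Compound 3, `O=C(O)CCn1c(=O)oc2cc(OCC3CCC3)c(Cl)cc21`, gives 25.1 nM in this assay, and this is the highest number of the three. The nearest of the others is compound 1, whose number is lower by a gap that lies beyond the scatter; compound 2 is furthest away, lower by a gap that also lies beyond the scatter. Compound 3 therefore stands as the weakest of the three on this read-out.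

Compound 4, `O=C(O)CCn1c(=O)oc2cc(OCc3ccccc3)c(Cl)cc21`, has not yet been measured. It differs from compound 3 in one place only: phenyl in place of cyclobutyl on a saturated chain carbon bound to an oxygen on an aromatic ring. Among the compounds with values here, no measured pair in this set shows exactly this change, so the size of the step can only be expected, not read off. Compound 1 and compound 2, which carry an aromatic ring in the corresponding region, both give lower numbers than compound 3, and a flat aromatic ring in place of the small saturated ring is expected to move compound 4 in the same direction, by a moderate step of a 2.1-fold lower number from compound 3 to compound 4 (0.32 log units; beyond the scatter). Compound 4 is accordingly estimated to give 12 nM in this assay, within a range from 4 nM to 40 nM.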

Compound 4, half-maximal inhibitory concentration: 25.1 nM
Compound 4: middle estimate off by 2.1-fold (0.32 log units), on the low side; the range from low to high includes it.
By their numbers in this assay, from the lowest: compounds 2 and 1 (each within the scatter of the next); then compounds 3 and 4 (each within the scatter of the next).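

In this assay, phenyl in place of cyclobutyl on a saturated chain carbon bound to an oxygen on an aromatic ring gives no change at the digits printed from compound 3 to compound 4 (within the scatter), the one direct test of this change among the compounds shown. For this pair, a six-membered aromatic ring of carbon and a four-membered non-aromatic ring of carbon cannot be told apart at this place, even though phenyl brings more heavy atoms than cyclobutyl, so neither the change in ring type nor the added size shifts the number here. Nothing measured here accounts for why the two groups read alike.

Compound 1 and compound 2 each differ from compound 4 in more than one place, so the compounds shown cannot say which of those differences, such as the methyl group on the chain carbon, goes with their values. Also open, on these data alone, is how the number would respond to a different group at this same place, such as an amine or a longer chain, with the rest of compound 4 left unchanged.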